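This account rests on a few compounds, and the source may have more. Where it says the series, first, only, none or still open, it means among the compounds named here.

Measured in a functional assay on A549 cells (Homo sapiens) for cytotoxicity, read by MTT assay, with a stated time of 48 h; a higher number here means a weaker inhibitor, a lower number a stronger inhibitor:
- Compound 1 `COc1c(OCc2ncc(C)o2)cc(O)c2c(=O)cc(-c3ccccc3)oc12`: > 100000 nM
- Compound 2 `CCCNCCOc1c(O)cc(O)c2c(=O)cc(-c3ccccc3)oc12`: "not determined" (no result reported)

Compound 1 stands at > 100000 nM, and this is a limit of the assay, not a number. Going by the values given here, the only other compound tested so far, compound 2, has no result, so no measured step is available as a guide.

The next compound to consider is compound 3 `COc1c(OCCCCN2CCN(C)CC2)cc(O)c2c(=O)cc(-c3ccccc3)oc12`. It carries 3-(4-methylpiperazin-1-yl)propyl in place of 5-methyl-1,3-oxazol-2-yl on a saturated chain carbon bound to an oxygen on an aromatic ring.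

Among the compounds with values here, with only this structural change to go on, a moderate move toward stronger inhibition is expected in this assay, though the result could still be only a limit. The expected step is an at least 3.3-fold lower number from compound 1 to compound 3 (0.52 log units; beyond the scatter). For compound 3 the estimated value is 30000 nM, with an expected range from 8000 nM to 100000 nM.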

Compound 3, half-maximal inhibitory concentration: 1500 nM
Estimate against measurement, compound 3: 20-fold (1.30 log units) above, and the stated range ends above it.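

In this assay, putting 3-(4-methylpiperazin-1-yl)propyl in place of 5-methyl-1,3-oxazol-2-yl gives an at least 66-fold lower number from compound 1 to compound 3 (1.82 log units; beyond the scatter). Going by these compounds alone, this is the first measured sign that the group on this saturated chain carbon bound to an oxygen on an aromatic ring can strongly change the result while the rest of compound 1 stays the same. The true size of the step remains unknown because the value for compound 1 is a limit and not a number: the limit of > 100000 nM in this assay, at which 1 of the 3 values shown sits.

A single pair cannot show whether the change comes from the 4-methylpiperazine ring, the chain that carries it, or the loss of the 5-methyl-1,3-oxazol-2-yl group. A morpholine ring or a dimethylamino group on the same chain, or the 4-methylpiperazine ring on a shorter chain, would help to separate these parts.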